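From Methoxy to Nitro at the Assay Limit

The compounds below may be only part of what the source reports. "The series", "measured", "known", "first", "only" and "open" are said of these compounds alone.

In a functional assay on NCI-H460 cells (Homo sapiens) for cytotoxicity, read by sulforhodamine B assay (a higher number here means a weaker inhibitor of growth, a lower number a stronger inhibitor of growth), compound 1 `CC1=CC[C@@H]([C@@](C)(O)CCCC(C)(C)NC=S)CC1` gives > 100000 nM, which is a limit and not a number. Compound 2 `CC1=CC[C@@H]([C@@](C)(O)CCCC(C)(C)NC(=S)N/N=C\c2ccc(C)cc2)CC1` gives > 100000 nM, also a limit. Compound 3 `COc1ccc(/C=N\NC(=S)NC(C)(C)CCC[C@](C)(O)[C@@H]2CC=C(C)CC2)cc1` stands at > 100000 nM, again a limit, so its place among the others cannot be ranked.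

Compound 4 `CC1=CC[C@@H]([C@@](C)(O)CCCC(C)(C)NC(=S)N/N=C\c2ccc([N+](=O)[O-])cc2)CC1` is reached from compound 3 by one change, nitro in place of methoxy on an aromatic carbon, para to a large group. For the measured compounds named here, the one measured step that bears on this change is a step that the two limits leave unreadable from compound 2 to compound 3, and it offers no size to carry over. The series as a whole shows only (the limit of > 100000 nM in this assay, at which 3 of the 3 values shown sit).

Going by the values given here, no measured step therefore points to a shift in either direction in this assay. The expected outcome is a number no higher from compound 3 to compound 4 (the limit leaves the size open), with no step beyond the usual scatter foreseen. For compound 4 the estimated value is 100000 nM. The expected range for compound 4 runs from 50000 nM to 200000 nM.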

Compound 4, concentration for total growth inhibition: > 100000 nM
Compound 4: only a limit was reported; the forecaster's own chance of this, stated with the estimate: 75%; the middle value lies on the limit itself.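

Compound 4, like compound 2 and compound 3, returned only a limit and not a number, so no step among these three compounds can be read in this assay. The compounds shown leave open whether any of them inhibits growth measurably, and whether the aromatic substituent matters, as every value is a limit: the limit of > 100000 nM in this assay, at which 4 of the 4 values shown sit.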